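Methoxy for methyl on the carbonyl of compound 1

This account rests on a few compounds, and the source may have more. Where it says the series, first, only, none or still open, it means among the compounds named here.

Values in a functional assay on the whole organism for agonist activity, with Mus musculus as the target; on this read-out higher numbers stand for an effect only at larger amounts of compound and lower numbers for an effect already at smaller amounts:
- Compound 1 `CC(=O)N(C)CC#CCN1CCCC1`: 0.55 mg/kg
- Compound 2 `CC(=O)N(C)CC#CCn1cncc1C`: 45 mg/kg
- Compound 3 `COC(=O)NCC#CCn1cncc1C`: > 100 mg/kg (a limit)

Not yet measured: compound 4 `COC(=O)N(C)CC#CCN1CCCC1`.

Of the two numerical values, the lower belongs to compound 1 at 0.55 mg/kg, with compound 2 at 45 mg/kg. Compound 3 gives only a limit, > 100 mg/kg.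

Compound 4 keeps the core of compound 1 and changes one group: methoxy in place of methyl on a carbonyl carbon. In words, this is methoxy in place of methyl on a carbonyl carbon, or acetyl to methoxycarbonyl.

Among the measured compounds shown here, one measured step bears on this change: an at least 2.2-fold higher number from compound 2 to compound 3 (0.34 log units; beyond the scatter). Its size is only a bound, since one end of it is a limit. It also covers more than the present change, as acetyl(methyl)amino gives way to (methoxycarbonyl)amino, and it sits on the core of compound 2, not that of compound 1. It therefore points to a higher number but sets the size only loosely, so a modest shift is expected. The expected change is a 2.2-fold higher number from compound 1 to compound 4 (0.34 log units; beyond the scatter). For compound 4 the estimated value is 1.2 mg/kg, with an expected range from 0.25 mg/kg to 6 mg/kg.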

Compound 4, dose for half-maximal effect: 5.5 mg/kg
Compound 4: middle estimate off by 4.6-fold (0.66 log units), on the low side; the range from low to high includes it.
By their numbers in this assay, from the lowest: compound 1; then compound 4; then compound 2. At a limit, above all of these: compound 3.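

In this assay, the change from acetyl to methoxycarbonyl now has a measured size on the shared core of the pair, with the methyl on the amide-type nitrogen kept and methoxy in place of methyl on a carbonyl carbon as the only difference: a 10-fold higher number from compound 1 to compound 4 (1.00 log units; beyond the scatter). The earlier step, an at least 2.2-fold higher number from compound 2 to compound 3 (0.34 log units; beyond the scatter), pointed the same way, but it sat on another core and also covered the change from acetyl(methyl)amino to (methoxycarbonyl)amino, so the carbonyl change could not be read alone. The value of compound 3 is a limit and not a number: the limit of > 100 mg/kg in this assay, at which 1 of the 4 values shown sits.

As far as these compounds go, whether an ethoxy group, a longer chain or an amine on the carbonyl carbon would raise or lower the number remains open, as does the size of the same change with hydrogen in place of methyl on the amide-type nitrogen. The two pairs also give no cause for the step, and they cannot show how far its size carries over to other cores.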